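Cytotoxicity on MT4 cells: from azetidine amide to acylsulfonamide

The source may report more compounds than this note shows. Statements on the series, on what has been measured and on what is new or still open speak of the compounds shown alone.

Compound 1 `Cc1cc(C)cc(S(=O)(=O)c2c(C(=O)NC3CNC3)[nH]c3ccc(Cl)cc23)c1`: 37300 nM
Compound 2 `Cc1cc(C)cc(S(=O)(=O)c2c(C(=O)N[C@H]3CCN(S(C)(=O)=O)C3)[nH]c3ccc(Cl)cc23)c1`: 29900 nM
Compound 3 `Cc1cc(C)cc(S(=O)(=O)c2c(C(=O)NC3CN(Cc4n[nH]c(=O)n4C)C3)[nH]c3ccc(Cl)cc23)c1`: 25200 nM

Of the compounds shown here, three sharing the core of compound 1 have been measured in an ADME assay on MT4 cells (Homo sapiens) for cytotoxicity, read by MTT assay, with a stated time of 5 days; on this read-out lower numbers stand for higher toxicity in this test and higher numbers for lower toxicity in this test. Compound 1 gives the highest of the three numbers, but its nearest neighbour is compound 2 with a 1.2-fold lower number from compound 1 to compound 2 (0.10 log units; within the scatter) and its furthest is compound 3 with a 1.5-fold lower number from compound 1 to compound 3 (0.17 log units; within the scatter), so none of the three is separated from the others beyond the scatter. Between compound 2 and compound 3 the step is a 1.2-fold lower number from compound 2 to compound 3 (0.07 log units; within the scatter).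

Compound 4 `Cc1cc(C)cc(S(=O)(=O)c2c(C(=O)NS(C)(=O)=O)[nH]c3ccc(Cl)cc23)c1` differs from compound 1 by methylsulfonyl in place of azetidin-3-yl on an amide-type nitrogen. For the measured compounds named here, the step that bears most directly on it is the one from compound 1 to compound 2, in which the azetidin-3-yl on the amide-type nitrogen was also exchanged, with no change beyond the scatter; the step to compound 3 points the same way. Compound 4 is therefore expected to show a step of a 1.2-fold lower number from compound 1 to compound 4 (0.07 log units; within the scatter), no change beyond the scatter, and its estimated value in this assay is 32000 nM with a range from 14000 nM to 70000 nM.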

Compound 4, half-maximal cytotoxic concentration: 40200 nM
The estimate for compound 4 lay 1.3-fold (0.10 log units) below the measured number; the range from low to high includes it.
By their numbers in this assay, from the lowest: compounds 3, 2, 1 and 4 (each within the scatter of the next).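

In this assay, taking the ring off the amide-type nitrogen altogether, with methylsulfonyl in place of azetidin-3-yl, gives a 1.1-fold higher number from compound 1 to compound 4 (0.03 log units; within the scatter) and thus no change beyond the scatter, so a ring at this position is not needed for the number to stay where it is. The same small group set against the larger ones gives a 1.3-fold higher number from compound 2 to compound 4 (0.13 log units; within the scatter) and a 1.6-fold higher number from compound 3 to compound 4 (0.20 log units; within the scatter), which means that across the four compounds, groups on this nitrogen ranging from 4 to 12 heavy atoms leave the read-out within the scatter. Nothing available explains this flatness.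

On these data alone, whether a carboxylic acid or a longer alkyl chain on this nitrogen would move the number beyond the scatter remains open. So does the effect of replacing the chlorine on the shared core with another group.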